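From methyl to methoxy: what to expect for compound 4

A few compounds are considered here, and "the series" means these few. Any claim that something is new, unique, unknown or untested is made for them only; others in the source may bear on it.

Measured so far in an ADME assay on HPC cells (Homo sapiens) for cytotoxicity, with a stated time of 24 h (on this read-out lower numbers stand for higher toxicity in this test and higher numbers for lower toxicity in this test), are these compounds:
- compound 1 `O=C1/C(=C/c2ccc(F)cc2)CCC/C1=C\c1ccccc1[N+](=O)[O-]` gives 11000 nM
- compound 2 `O=C1/C(=C/c2ccc(Cl)cc2)CCC/C1=C\c1ccccc1[N+](=O)[O-]` gives 400000 nM
- compound 3 `Cc1ccc(/C=C2\CCC/C(=C\c3ccccc3[N+](=O)[O-])C2=O)cc1` gives > 400000 nM (a limit, not a number)

Compound 3 stands at > 400000 nM and this is a limit of this assay rather than a number. Compound 4 `COc1ccc(/C=C2\CCC/C(=C\c3ccccc3[N+](=O)[O-])C2=O)cc1` has methoxy in place of methyl on an aromatic carbon and differs from compound 3 nowhere else.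

Three measured steps swap a group on an aromatic carbon. Two are large and beyond the scatter: a 36-fold higher number from compound 1 to compound 2 (1.56 log units; beyond the scatter) and then an at least 36-fold higher number from compound 1 to compound 3 (1.56 log units; beyond the scatter) as well. The third shows a number no lower from compound 2 to compound 3 (the limit leaves the size open) and leaves its size open. Within the data shown here, none of them involves methoxy, so they show only that such a swap can matter.

A value close to compound 2 at 400000 nM is expected, which means a modest step down, while compound 1 at 11000 nM shows that a much lower number is possible. For compound 4 the estimated value is 250000 nM with an expected range from 60000 nM to 400000 nM in this test. The expected change is an at least 1.6-fold lower number from compound 3 to compound 4 (0.20 log units; that floor lies within the scatter) by this estimate.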

Compound 4, half-maximal cytotoxic concentration in the HPC assay: > 400000 nM
Compound 4: a limit, no number; the forecaster's own chance of this, stated with the estimate: 45%; at least 1.6-fold (0.20 log units) between middle value and limit.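

Methoxy at this place, para to a large group, joins methyl at the limit of the HPC assay, so the step from compound 3 to compound 4 cannot be read, and this read-out does not separate the two groups: the limit of > 400000 nM in the HPC assay, at which 2 of the 4 values shown sit.

Against chloro there is a number no lower from compound 2 to compound 4 (the limit leaves the size open). Fluoro stays alone at the low end, with an at least 36-fold higher number from compound 1 to compound 4 (1.56 log units; beyond the scatter).

In a physicochemical assay for lipophilicity (a lower number here means a more polar compound, a higher number a more lipophilic compound), compound 3 gives 5.15 and compound 4 gives 4.76. Compound 4 is the more polar of the pair in the physicochemical assay, with a number 0.39 log units lower from compound 3 to compound 4 (beyond the scatter), yet no change in toxicity in this test can be read: the measured partition coefficient of compound 3, 5.15, and of compound 4, 4.76, a number 0.39 log units lower (beyond the scatter)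

From the compounds shown here alone, how far compound 3 and compound 4 lie beyond the limit stays open. Also open, going by these compounds, is whether an amine, a carboxylic acid or a longer chain such as ethoxy at this place would give a number lower than the limit, as fluoro does in compound 1.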